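Shrinking the amide ring of compound 1

The compounds below may be only part of what the source reports. "The series", "measured", "known", "first", "only" and "open" are said of these compounds alone.

Compound 1 `COc1ccc(C[C@@H](O)/C=C/C=C/C(=O)N2CCCCC2)cc1OC` gives 39500 nM in a functional assay on MCF7 cells (Homo sapiens) for antiproliferative activity, read by sulforhodamine B assay, with a stated time of 48 h (on this read-out lower numbers stand for stronger inhibition and higher numbers for weaker inhibition), the highest of the three numbers measured. Compound 2 `CCN1CCN(C(=O)/C=C/C=C/[C@H](O)Cc2ccc(OC)c(OC)c2)CC1` gives 11500 nM and compound 3 `COc1ccc(C[C@@H](O)/C=C/C=C/C(=O)N2CCN(C(c3ccccc3)c3ccccc3)CC2)cc1OC` gives 12500 nM. Among the compounds with values here, the one step between measured neighbours, a 3.4-fold lower number from compound 1 to compound 2 (0.54 log units; beyond the scatter), shows that exchanging the amide ring of compound 1 for another ring can lower the number modestly. Compound 4 `COc1ccc(C[C@@H](O)/C=C/C=C/C(=O)N2CCCC2)cc1OC` differs from compound 1 by pyrrolidin-1-yl in place of piperidin-1-yl on a carbonyl carbon. Within the data shown here, no measured step exchanges one saturated ring for a smaller one, so the step to compound 2 bears on it only loosely. For compound 4 a change within the scatter, or at most a slight lowering, is expected, a 1.3-fold lower number from compound 1 to compound 4 (0.12 log units; within the scatter). The estimate for compound 4 is 30000 nM, with a range from 12000 nM to 80000 nM.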

Compound 4, half-maximal inhibitory concentration: 26200 nM
Beside the measured number, compound 4's estimate is 1.1-fold (0.06 log units) above it; the measured number falls inside the stated range.
By their numbers in this assay, from the lowest: compounds 2 and 3 (each within the scatter of the next); then compounds 4 and 1 (each within the scatter of the next).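

In this assay, within the data shown here, the first measured exchange of a saturated ring for a smaller one on this carbonyl carbon, a 1.5-fold lower number from compound 1 to compound 4 (0.18 log units; within the scatter), does not separate pyrrolidin-1-yl from piperidin-1-yl. Against 4-ethylpiperazin-1-yl, the pyrrolidin-1-yl amide shows a 2.3-fold higher number from compound 2 to compound 4 (0.36 log units; beyond the scatter), so of these three rings only 4-ethylpiperazin-1-yl stands apart. Nothing available explains that gap. On these data alone, whether a morpholine ring or an open-chain diethylamino group on the carbonyl carbon would fall with compound 1 and compound 4 or with compound 2 remains open.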